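Cyclopropylmethyl uronamide in the adenosine A3 binding series

This account rests on a few compounds, and the source may have more. Where it says the series, first, only, none or still open, it means among the compounds named here.

Measured so far:
compound 1 `CNC(=O)[C@H]1O[C@@H](n2cnc3c(NC)nc(Cl)nc32)[C@H](O)[C@@H]1O` gives 0.282 nM in an assay on CHO cells for displacement of a labelled ligand from adenosine receptor A3 (Homo sapiens); a lower number here means a stronger inhibitor, a higher number a weaker inhibitor
compound 2 `CNc1nc(Cl)nc2c1ncn2[C@@H]1O[C@H](C(=O)N(C)C)[C@@H](O)[C@H]1O` gives 1510 nM in this assay
compound 3 `CNc1nc(Cl)nc2c1ncn2[C@@H]1O[C@H](C(=O)NC2CC2)[C@@H](O)[C@H]1O` gives 2.82 nM in this assay

Compound 3 stands second of the three in this assay, separated from compound 1 by a 10-fold higher number from compound 1 to compound 3 (1.00 log units; beyond the scatter) and from compound 2 by a 540-fold lower number from compound 2 to compound 3 (2.73 log units; beyond the scatter). The step under study leads to compound 4 `CNc1nc(Cl)nc2c1ncn2[C@@H]1O[C@H](C(=O)NCC2CC2)[C@@H](O)[C@H]1O`, not yet measured; the change is cyclopropylmethyl in place of cyclopropyl on an amide-type nitrogen.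

Going by the values given here, two measured steps bear on changes at this amide-type nitrogen. Enlarging the substituent from methyl to cyclopropyl gave a 10-fold higher number from compound 1 to compound 3 (1.00 log units; beyond the scatter), a modest loss. Replacing the amide hydrogen with methyl gave a 5400-fold higher number from compound 1 to compound 2 (3.73 log units; beyond the scatter), a large loss, which does not apply here since the hydrogen remains in compound 4. A further lengthening of the substituent is therefore expected to cost something, in the direction of a higher number, of a size in this assay comparable to the modest step already seen rather than the large one; the expected step is a 3.5-fold higher number from compound 3 to compound 4 (0.55 log units; beyond the scatter). For compound 4 the estimate in this assay is 10 nM, with a range of 2.5 nM to 50 nM.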

Compound 4, inhibition constant: 1.1 nM
Beside the measured number, compound 4's estimate is 9.1-fold (0.96 log units) above it, and the stated range ends above it.
By their numbers in this assay, from the lowest: compound 1; then compound 4; then compound 3; then compound 2.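

In this assay, cyclopropylmethyl in place of cyclopropyl on the amide-type nitrogen gives a 2.6-fold lower number from compound 3 to compound 4 (0.41 log units; beyond the scatter), so enlarging this substituent does not steadily raise the number: compound 3 stands out of line with a simple ordering by substituent size among the secondary amides. The methyl amide still keeps a modest lead, with a 3.9-fold higher number from compound 1 to compound 4 (0.59 log units; beyond the scatter), while keeping the amide hydrogen remains far more favourable than the dimethylamino arrangement, with a 1400-fold lower number from compound 2 to compound 4 (3.14 log units; beyond the scatter). Nothing at hand accounts for the gain of the cyclopropylmethyl group over the cyclopropyl group.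

Open, going by these compounds, is whether a 2-cyclopropylethyl or cyclobutylmethyl group on this nitrogen would extend the gain or reverse it. Also open, on these data alone, is whether the ring matters at all, which an open-chain isobutyl group would test.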